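The source may hold more compounds than are shown below. What is called first, only, known or untested is meant among the compounds shown, and "the series" means these compounds.

Compound 1, `O=C1C(Nc2ccc(F)cc2F)=CC(=O)c2ncccc21`, and compound 2, `O=C1C(Nc2ccc(Br)cc2)=CC(=O)c2ncccc21`, share one core and differ only in the aromatic amine attached to it. In a functional assay on the whole organism (aorta) with Rattus norvegicus as the target (on this read-out higher numbers stand for larger maximal responses and lower numbers for smaller maximal responses), compound 1 reaches 94%, and in this assay compound 2 reaches 88%. Among the measured compounds shown here, compound 2 stands at one of only two numbers in hand, and its figure lies within the usual scatter of the figure of compound 1, so the two cannot be told apart. Compound 3, `O=C1C(Nc2ccc(OC(F)(F)F)cc2)=CC(=O)c2ncccc21`, is the next member, and it has not yet been tested in this assay. Its structure differs from compound 2 in one place: trifluoromethoxy in place of bromo on an aromatic carbon. For the measured compounds named here, with no measured pair showing how such a replacement moves the response, the expectation for the step from compound 2 to compound 3 in this assay is a number 2 percentage points higher from compound 2 to compound 3 (within the scatter), that is, no shift beyond the scatter in either direction. Compound 3 is therefore estimated at 90% in this assay, expected between 75% and 100%.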

Compound 3, largest response reached (Emax), in percent of the reference or control that the assay uses: 88%
Beside the measured number, compound 3's estimate is 2 percentage points above it, within the range that was stated.
By their numbers in this assay, from the lowest: compounds 2, 3 and 1 (each within the scatter of the next).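

In this assay, putting trifluoromethoxy in place of bromo on an aromatic carbon, para to a large group, gives no change at the digits printed from compound 2 to compound 3 (within the scatter). Among the compounds shown here, this is the only step in hand at this position, and it shows that a group of five heavy atoms with one hydrogen-bond acceptor can stand where a single bromine stood, with a response that cannot be told apart from that of compound 2. That finding holds for this one pair and this one read-out.

Nothing measured here bears on why the exchange leaves the response where it is. As far as these compounds go, whether an amine, a carboxylic acid or a longer chain on the same aromatic carbon would also stay within the scatter of compound 2 remains open.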